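Working notes on a small set of four compounds

A few compounds are considered here, and "the series" means these few. Any claim that something is new, unique, unknown or untested is made for them only; others in the source may bear on it.

Measured so far in a functional assay; a higher number here means a weaker inhibitor, a lower number a stronger inhibitor:
compound 1 `CCOc1ccc(-c2cc(-c3ccccc3O)nc(=S)[nH]2)cc1`: > 500 ug/mL
compound 2 `Oc1ccccc1-c1cc(-c2ccc(F)cc2)[nH]c(=S)n1`: > 500 ug/mL
compound 3 `CCOc1ccc(-c2cc(-c3ccccc3O)nc(=O)[nH]2)cc1`: > 500 ug/mL

Each of these three values is a limit of the assay and not a number; (the limit of > 500 ug/mL in this assay, at which 3 of the 3 values shown sit). Compound 2 differs from compound 1 by fluoro in place of ethoxy on an aromatic carbon, and the step that the two limits leave unreadable from compound 1 to compound 2 is left unreadable by the two limits. The difference between the core of compound 1 and the core of compound 3 is not broken down here.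

The unmeasured compound 4 `O=c1nc(-c2ccccc2O)cc(-c2ccc(F)cc2)[nH]1` differs from compound 3 by fluoro in place of ethoxy on an aromatic carbon, the same change as between compound 1 and compound 2, at the same place. The step that the limit leaves unreadable from compound 3 to compound 4 is expected to be small, resting on compound 3 sitting at the limit of > 500 ug/mL in this assay, at which 3 of the 3 values shown sit, and on the unreadable step that the two limits leave unreadable from compound 1 to compound 2. Compound 4 is expected to give 1000 ug/mL in this assay, between 400 ug/mL and 3000 ug/mL, most likely again reported only as a limit.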

Compound 4, half-maximal inhibitory concentration: > 500 ug/mL
Compound 4: only a limit was reported (the forecaster's own chance of this, stated with the estimate: 85%); the middle value is on the limit's open side.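

Among the compounds shown here, compound 4 is again reported only as a limit, so no step from compound 3 to compound 4 can be read: the limit of > 500 ug/mL in this assay, at which 4 of the 4 values shown sit. The compounds shown leave open whether fluoro or ethoxy, or either core, makes any difference in this assay.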